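A few compounds are considered here, and "the series" means these few. Any claim that something is new, unique, unknown or untested is made for them only; others in the source may bear on it.

The series rests on one shared core, seen in compound 1 `CCOC(=O)c1oc2ccc(NS(=O)(=O)c3ccc(Br)cc3)cc2c1C`. In a functional assay on HCT-116 cells (Homo sapiens) for inhibition, read by MTT assay, with a stated time of 72 h (a lower number here means a stronger inhibitor, a higher number a weaker inhibitor), compound 1 gives 9310 nM. Compound 2 `CCOC(=O)c1oc2ccc(N(Cc3ccccc3)S(=O)(=O)c3ccc(Br)cc3)cc2c1C` carries a benzyl on the sulfonamide nitrogen, and in this assay compound 2 gives 9460 nM, so that the step of a 1.0-fold higher number from compound 1 to compound 2 (0.01 log units; within the scatter). Compound 3 `CCOC(=O)c1oc2ccc(N(Cc3ccccc3)S(=O)(=O)c3cccc(Br)c3)cc2c1C` has 3-bromophenyl in place of 4-bromophenyl on the sulfonyl sulfur. In this assay compound 3 reaches only a limit of the assay, > 40000 nM. Compound 3 thus sits at the limit of > 40000 nM in this assay, at which 1 of the 3 values shown sits. The step of an at least 4.2-fold higher number from compound 2 to compound 3 (0.62 log units; beyond the scatter) ran toward weaker inhibition and was at least modest.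

Compound 4 `CCOC(=O)c1oc2ccc(N(Cc3ccccc3)S(=O)(=O)c3ccccc3Br)cc2c1C` has not yet been measured. It differs from compound 3 by 2-bromophenyl in place of 3-bromophenyl on a sulfonyl sulfur. Within the data shown here, no measured step places the bromine at this position; the only step that bears on the sulfonyl ring is the one from compound 2 to compound 3, which was beyond the scatter and weakened inhibition, while the benzyl step was within the scatter. With compound 3 already at the limit, the step is expected to be a step that the limit leaves unreadable from compound 3 to compound 4. For compound 4 the estimate in this assay is 45000 nM, with a range from 15000 nM to 130000 nM.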

Compound 4, half-maximal inhibitory concentration: > 40000 nM
Compound 4 ended at the assay's limit; the forecaster's own chance of this, stated with the estimate: 65%; the middle value lies beyond the limit too.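

Placing the bromine as in 2-bromophenyl on the sulfonyl sulfur gave an at least 4.2-fold higher number from compound 2 to compound 4 (0.62 log units; beyond the scatter) in this assay, so a second bromophenyl isomer now departs from 4-bromophenyl toward weaker inhibition, as 3-bromophenyl did. In this assay compound 4 gives > 40000 nM, which is a limit of the assay and not a number. Among the benzyl compounds 2, 3 and 4, only the 4-bromophenyl compound has a readable value, and the step between the 3-bromophenyl and 2-bromophenyl compounds cannot be read, so these two cannot be ordered against each other: the limit of > 40000 nM in this assay, at which 2 of the 4 values shown sit.

As far as these compounds go, how far inhibition falls past the limit for compound 3 and compound 4 stays open. Also open, from the compounds shown here alone, is whether a chlorine, a methoxy group or a carboxylic acid in place of the bromine on the sulfonyl ring would keep the level of compound 2, at 9460 nM. Going by these compounds, it is also open whether 2-bromophenyl or 3-bromophenyl would behave the same way with the hydrogen of compound 1 on the sulfonamide nitrogen rather than a benzyl.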